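The compounds below may be only part of what the source reports. "The series", "measured", "known", "first", "only" and "open" are said of these compounds alone.

Compound 1 `CCCC/C=C\CCCCCCCCCc1cc(=O)c2c(O)c(C)c(OCOC)cc2o1`: > 87000 nM
Compound 2 `CCCCCCCCCCCCCCCc1cc(=O)c2c(O)c(C)c(OCOC)cc2o1`: > 87000 nM

In a functional assay on MDA-MB-231 cells (Homo sapiens) for antiproliferative activity, read by MTT assay (a higher number here means a weaker inhibitor, a lower number a stronger inhibitor), compound 2 gives > 87000 nM, which is a limit and not a number. Compound 1 gives > 87000 nM, also a limit. Within the data shown here, the only measured step, a step that the two limits leave unreadable from compound 1 to compound 2, lies in the chain and has no readable size, so it does not bear on the next change. All the data sit at one limit: the limit of > 87000 nM in this assay, at which 2 of the 2 values shown sit.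

Compound 3 `CCCCCCCCCCCCCCCc1cc(=O)c2c(O)c(C)c(O)cc2o1` differs from compound 2 by hydrogen in place of methoxymethyl on an oxygen on an aromatic ring. With no measured guide, a modest move towards stronger inhibition is expected, as an at least 2.9-fold lower number from compound 2 to compound 3 (0.46 log units; beyond the scatter). The estimate for compound 3 is 30000 nM, with an expected range from 8000 nM to 87000 nM.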

Compound 3, half-maximal inhibitory concentration: 42800 nM
Beside the measured number, compound 3's estimate is 1.4-fold (0.15 log units) below it, within the range that was stated.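

Compound 3 is the first compound shown to give a number and not a limit in this assay. Hydrogen in place of methoxymethyl on this oxygen gives an at least 2.0-fold lower number from compound 2 to compound 3 (0.30 log units; that floor lies within the scatter), so the true size of the change stays unknown. The step is only a floor because compound 2 stands at a limit of the assay: the limit of > 87000 nM in this assay, at which 2 of the 3 values shown sit.

From the compounds shown here alone, it remains open how an amine or a methoxy group in place of this hydroxy would read. Going by these compounds, it also remains open whether the hex-1-en-1-yl chain end of compound 1 would read differently with the hydroxy in place.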